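This account rests on a few compounds, and the source may have more. Where it says the series, first, only, none or still open, it means among the compounds named here.

Measured so far in a functional assay on HeLa cells (Homo sapiens) for antiproliferative activity, read by MTT assay, with a stated time of 48 h; on this read-out higher numbers stand for weaker inhibition of growth and lower numbers for stronger inhibition of growth:
- compound 1 `COC(=O)N1N=C(c2ccccc2)CC1c1cc(OC)c(OC)c(OC)c1`: 2180 nM
- compound 2 `CCCOC(=O)N1N=C(c2cccc(OC)c2)CC1c1cc(OC)c(OC)c(OC)c1`: > 10000 nM (a limit)
- compound 3 `COC(=O)N1N=C(c2ccc(OC)cc2)CC1c1cc(OC)c(OC)c(OC)c1`: 2590 nM

Among the compounds with values here, compound 3 cannot be separated from compound 1 on these numbers, as the one measured step is a 1.2-fold higher number from compound 1 to compound 3 (0.07 log units; within the scatter). Compound 4 `CCCOC(=O)N1N=C(c2ccc(OC)cc2)CC1c1cc(OC)c(OC)c(OC)c1` differs from compound 3 by ethyl in place of hydrogen on a saturated chain carbon bound to an oxygen next to a carbonyl group, which reads as methoxycarbonyl to propoxycarbonyl. Within the data shown here, no measured step isolates this change. Compound 2 also carries propoxycarbonyl but differs from compound 3 in a second place as well. The reading of compound 2, > 10000 nM, is a limit. The methoxy step above stayed within the scatter, so the expectation leans on that limit. A move to a higher number in this assay, meaning weaker inhibition of growth, is expected, an estimated 3.1-fold higher number from compound 3 to compound 4 (0.49 log units; beyond the scatter). The expected value for compound 4 is 8000 nM, within an estimated range of 3000 nM to 30000 nM.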

Compound 4, concentration for 50% growth inhibition: > 10000 nM
Compound 4 ended at the assay's limit; the forecaster's own chance of this, stated with the estimate: 45%; middle value at least 1.2-fold (0.09 log units) away from the limit.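

Methoxycarbonyl to propoxycarbonyl now has a step of its own in this assay: an at least 3.8-fold higher number from compound 3 to compound 4 (0.58 log units; beyond the scatter), meaning weaker inhibition of growth. The value of compound 4, > 10000 nM, is a limit. The step from compound 2 to compound 4 cannot be read, so 4-methoxyphenyl and 3-methoxyphenyl cannot be ranked with propoxycarbonyl in place: the limit of > 10000 nM in this assay, at which 2 of the 4 values shown sit.

Open, on these data alone, is whether ethoxycarbonyl at this place would read like compound 3 or like compound 4. Also open, as far as these compounds go, is how a carboxylic acid or an amide would read there.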